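Methyl on the Core: Two Steps, One Expectation

A few compounds are considered here, and "the series" means these few. Any claim that something is new, unique, unknown or untested is made for them only; others in the source may bear on it.

Four compounds share the idea of a thio-imidamide chain attached to a six-membered aromatic ring with 2 nitrogen, and all are judged in a functional assay on the whole organism (stomach) for inhibition, with Rattus norvegicus as the target, at a dose of 100 mg/kg by the intraduodenal route; a lower number here means less inhibition, a higher number more inhibition at the dose given (going by the name of the read-out). Compound 1 `CC(Cn1ncccc1=O)C(=N)S` gives 40.3% in this assay. Compound 3 `N=C(S)CCn1nc(-c2ccccc2)ccc1=O` gives 53.7%, and compound 2 `Cc1cc(=O)n(CCC(=N)S)nc1-c1ccccc1` gives 32%. The cores of compound 1 and compound 3 are different, and the difference between the two cores is not broken down here.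

The step from compound 3 to compound 2 is a single change, (methyl in place of hydrogen on an aromatic carbon), and it moved the read-out as a number 21.7 percentage points lower from compound 3 to compound 2 (beyond the scatter). The unmeasured compound 4 `Cc1ccc(=O)n(CC(C)C(=N)S)n1` arises from compound 1 by methyl in place of hydrogen on an aromatic carbon. This is the same kind of change as the one from compound 3 to compound 2, and it is the second of only two such steps among these compounds, but the surroundings differ: in compound 2 the methyl is ortho to a phenyl group (6 heavy atoms), opposite the ring nitrogen and para to a group of 5 heavy atoms, whereas in compound 4 it is next to the ring nitrogen, meta to a group of 6 heavy atoms and para to a group of 1 heavy atom.

Resting on that one measured step, compound 4 is expected to show a number 13.3 percentage points lower from compound 1 to compound 4 (beyond the scatter), a drop of roughly the kind seen before, though with wide uncertainty because a number 21.7 percentage points lower from compound 3 to compound 2 (beyond the scatter) was measured on a different core. The estimate for compound 4 is therefore 27%, between 8% and 46%.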

Compound 4, a percentage reported as inhibition, in the whole organism at one dose (the size of the read-out at that dose, not a potency): 30.2%
Compound 4: middle estimate off by 3.2 percentage points, on the low side; low and high end bracket the measured number.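

In this assay, methyl in place of hydrogen on an aromatic carbon gave a number 10.1 percentage points lower from compound 1 to compound 4 (beyond the scatter), so the change went in the same direction on the core of compound 1 as it had on the core of compound 3. Set side by side, the two steps agree in direction, and the gap between their sizes is no larger than repeated measurements of this kind would produce: the same change on two cores in this assay, a number 21.7 percentage points lower (beyond the scatter) from compound 3 to compound 2 and a number 10.1 percentage points lower (beyond the scatter) from compound 1 to compound 4, 11.6 percentage points apart, within the scatter of two such steps This shows that, across these two cores, the drop carried over, but two steps are a small sample, the methyl does not sit in the same surroundings in the two cases, and the read-out records the effect at a single dose rather than a potency, so the result gives neither a reason for the drop nor any assurance that a third core would behave alike.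

The compounds shown leave open whether another group on that aromatic carbon, such as an ethyl group or an amine, would go the same way as methyl. They also leave open how the read-out would respond if the thio-imidamide chain gave way to a longer chain or a carboxylic acid.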